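Piperidine amide variation on a peroxide core

A few compounds are considered here, and "the series" means these few. Any claim that something is new, unique, unknown or untested is made for them only; others in the source may bear on it.

Within the data shown here, compound 1 `O=C(C[C@H]1CC[C@]2(CC1)OO[C@]1(O2)C2CC3CC(C2)CC1C3)N1CCNCC1` is the only member with a number: in an in vivo ADME assay on the whole organism (blood, strain Sprague-Dawley) for pharmacokinetics, with Rattus norvegicus as the target, given by the intravenous route (a higher number here means faster removal of the compound, a lower number slower removal), compound 1 gives 56.3 mL/min/kg. Compound 2 `O=C(C[C@H]1CC[C@]2(CC1)OO[C@]1(O2)C2CC3CC(C2)CC1C3)N1CCC(O)CC1` in this assay is reported as "not determined" (no result reported) and so stands without a number. Compound 3 `NC1CCN(C(=O)C[C@H]2CC[C@]3(CC2)OO[C@]2(O3)C3CC4CC(C3)CC2C4)CC1` differs from compound 2 by amino in place of hydroxy on a saturated ring carbon. Since compound 2 carries no number, no step can be read from this pair; the expectation is a result in this assay near that of compound 1, with no step beyond the scatter anticipated in either direction, because compound 1 gives 56.3 mL/min/kg from the same core. Compound 3 is expected to give 50 mL/min/kg, within 25 mL/min/kg to 100 mL/min/kg.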

Compound 3, clearance: 39.1 mL/min/kg
The estimate for compound 3 lay 1.3-fold (0.11 log units) above the measured number, and the stated range covers the measured number.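

In this assay, moving from piperazin-1-yl to 4-aminopiperidin-1-yl on a carbonyl carbon gives a 1.4-fold lower number from compound 1 to compound 3 (0.16 log units; within the scatter), so this exchange of one amine-bearing amide for another leaves no step beyond the scatter. Among these compounds, this is the first readable step at this position of the series, and it concerns the amide group only, with the shared core unchanged. Nothing at hand bears on the reason for these values. Steps involving compound 2 cannot be read, so amino against hydroxy remains unsettled. Also open, going by these compounds, is how a carboxylic acid or a dimethylamino group on that saturated ring carbon would read in this assay.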